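Mirror-Image Pair Compared for Cytotoxicity in Human Fibroblasts

The compounds below may be only part of what the source reports. "The series", "measured", "known", "first", "only" and "open" are said of these compounds alone.

Among the compounds with values here, compound 1 `O=[N+]([O-])c1cn2c(n1)[S@+]([O-])C[C@@H](OCc1ccc(OC(F)(F)F)cc1)C2` is the only member of this small set with a single number in an ADME assay on MRC5 cells (Homo sapiens) for cytotoxicity; on this read-out higher numbers stand for weaker inhibition and lower numbers for stronger inhibition; in that assay compound 1 gives 50000 nM. Compound 2 `O=[N+]([O-])c1cn2c(n1)[S+]([O-])CC(OCc1ccc(OC(F)(F)F)cc1)C2` is drawn without a defined configuration at the two places where compound 1 carries its stereocentres. In this assay compound 2 gives 60000 nM; > 64000 nM (2 entries). Compound 3 `O=[N+]([O-])c1cn2c(n1)[S@@+]([O-])C[C@H](OCc1ccc(OC(F)(F)F)cc1)C2` has not yet been measured in this assay. It differs from compound 1 as follows: the two compounds have the same atoms and bonds and differ only in configuration as drawn: 2 of 2 stereo elements differ (all stereocentres are inverted: mirror images); a stereocentre at a sulfur is drawn R in compound 1 and S in compound 3; a stereocentre at a saturated ring carbon is drawn S in compound 1 and R in compound 3. Within the data shown here, no step between two measured compounds is available for this pair, so the expectation rests on the several entries of compound 2 in this assay, 60000 nM; > 64000 nM (2 entries) together with the fact that one of compounds 1 and 2 is drawn with a defined configuration and the other without, at the place where they differ, which place compound 2 close to compound 1 on this read-out. On that basis the step of a 1.1-fold higher number from compound 1 to compound 3 (0.04 log units; within the scatter) is expected to lie within the usual scatter, with no clear direction. Compound 3 is therefore estimated at 55000 nM in this assay, with a range from 30000 nM to 100000 nM, and a real chance that only a limit is reported.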

Compound 3, half-maximal inhibitory concentration: > 64000 nM
Compound 3 gave a limit, no number; the forecaster's own chance of this, stated with the estimate: 40%; middle value at least 1.1-fold (0.06 log units) from the limit.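

Compound 3 returns only a limit of the assay in this assay, > 64000 nM, not a number. The mirror-image pair gives an at least 1.2-fold higher number from compound 1 to compound 3 (0.10 log units; that floor lies within the scatter), so at this floor, inverting both the stereocentre at the sulfur and the stereocentre at the saturated ring carbon shows no difference beyond the scatter, while the limit leaves the upper end of the step unfixed. Where the earlier compounds offered one defined configuration and the undefined drawing of compound 2, both mirror images now stand separately, and any gap between them could rest on configuration alone: the fact that compounds 1 and 3 differ only in the configuration as drawn

As far as these compounds go, the true size of the step stays open, as does the separate share of the sulfur and of the saturated ring carbon, for the two centres change together in this pair. Equally open, from the compounds shown here alone, is how an amine or a carboxylic acid on the shared core would read in this assay.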